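Aryl swap on the ring nitrogen: expectation for compound 3

The compounds below may be only part of what the source reports. "The series", "measured", "known", "first", "only" and "open" are said of these compounds alone.

Compound 2 `Nc1scc(CN2CCN(c3cccc4ccccc34)CC2)c1C(=O)c1ccc(Cl)cc1` stands highest of the two numbers measured in a functional assay on CHO cells with adenosine receptor A1 (Homo sapiens) as the target, read by cAMP accumulation and immunoassay, with a stated time of 6 min, tested at 1 uM (on this read-out higher numbers stand for a weaker effect at the one concentration tested and lower numbers for a stronger effect), where compound 2 gives 2.9%. Compound 1 `Nc1scc(CN2CCN(c3ccc(Cl)c(C(F)(F)F)c3)CC2)c1C(=O)c1ccc(Cl)cc1` in this assay gives -47%. Going by the values given here, the one measured step, a number 49.9 percentage points higher from compound 1 to compound 2 (beyond the scatter), shows that the group on the amine nitrogen in the ring moves the read-out far beyond the scatter. Compound 3 `Nc1scc(CN2CCN(c3ccccc3F)CC2)c1C(=O)c1ccc(Cl)cc1` differs from compound 2 only at that place: 2-fluorophenyl in place of naphthalen-1-yl on an amine nitrogen in a ring. Among the compounds with values here, no measured step covers 2-fluorophenyl at this position, so only the size of the single step already seen bears on the expectation: a change of the aryl group here can shift the number well beyond the scatter, and the direction for 2-fluorophenyl is not fixed by the data. Compound 3 is therefore expected to give -15% in this assay, within -55% to 25%. For compound 3 the expected step is a number 17.9 percentage points lower from compound 2 to compound 3 (beyond the scatter), leaning toward a stronger effect with wide uncertainty.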

Compound 3, a percentage reported as activity, at one concentration (the size of the read-out at that concentration, not a potency): -9.2%
Beside the measured number, compound 3's estimate is 5.8 percentage points below it, and the stated range covers the measured number.
By their numbers in this assay, from the lowest: compound 1; then compound 3; then compound 2.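

In this assay the series gives a number 12.1 percentage points lower from compound 2 to compound 3 (beyond the scatter) and a number 37.8 percentage points higher from compound 1 to compound 3 (beyond the scatter) when 2-fluorophenyl takes the place on the amine nitrogen in the ring. The position therefore responds to a third aryl group, with the modest step from the naphthalen-1-yl compound and the large step from the 4-chloro-3-(trifluoromethyl)phenyl compound both printed as beyond the scatter. Two phenyl groups carrying different substituents do not read alike here, so the presence of a phenyl ring does not by itself set the number.

Still open, from the compounds shown here alone, is whether the fluorine or its place on the phenyl ring accounts for the step, a question that an unsubstituted phenyl or a 4-fluorophenyl group would address. Going by these compounds, how a pyridinyl ring on this nitrogen would read also remains open. No measurement among these data offers a reason for these differences.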